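A few compounds are considered here, and "the series" means these few. Any claim that something is new, unique, unknown or untested is made for them only; others in the source may bear on it.

In an ADME assay on MT4 cells (Homo sapiens) for cytotoxicity, read by MTT assay, with a stated time of 5 days (on this read-out lower numbers stand for higher toxicity in this test and higher numbers for lower toxicity in this test), the compounds measured so far are:

Compound 1 `COc1cc2nc([S+]([O-])CC(=O)Nc3cccc([N+](=O)[O-])c3)nc(Nc3c(Cl)cc(/C=C/C#N)cc3Cl)c2cc1OC`: >= 83200 nM, a limit of the assay.
Compound 2 `COc1cc2nc([S+]([O-])CC(=O)Nc3ccc(Cl)cc3)nc(Nc3c(Cl)cc(/C=C/C#N)cc3Cl)c2cc1OC`: 14400 nM.

Among the compounds with values here, compound 2 is the only compound here with an actual number, 14400 nM. Compound 3 `COc1cc2nc([S+]([O-])CC(=O)Nc3ccccc3C(F)(F)F)nc(Nc3c(Cl)cc(/C=C/C#N)cc3Cl)c2cc1OC` differs from it at one place: 2-(trifluoromethyl)phenyl in place of 4-chlorophenyl on an amide-type nitrogen. Within the data shown here, the single measured step at this place is an at least 5.7-fold lower number from compound 1 to compound 2 (0.76 log units; beyond the scatter). Going by these compounds, its full size is unknown, and it involves different groups, so it gives no direction for the new change. In this assay, no shift beyond the scatter is therefore expected, and the estimated step is a 1.4-fold higher number from compound 2 to compound 3 (0.14 log units; within the scatter). For compound 3, the expected value is 20000 nM, with an estimated range of 7000 nM to 70000 nM.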

Compound 3, half-maximal cytotoxic concentration: > 192000 nM
Compound 3 gave a limit, no number (the forecaster's own chance of this, stated with the estimate: 20%); at least 9.6-fold (0.98 log units) between middle value and limit.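

In this assay, the change on the amide-type nitrogen gives an at least 13-fold higher number from compound 2 to compound 3 (1.12 log units; beyond the scatter), so this place can also move the read-out upward from compound 2, which the earlier step did not show. Compound 3 gave a limit of the assay, not a number: the limit of > 192000 nM in this assay, at which 1 of the 3 values shown sits. Compound 1 also gave a limit, so the step between compound 1 and compound 3 cannot be read.

Going by these compounds, it remains open whether the higher number follows the trifluoromethyl group or its place on the ring. Neither 2-chlorophenyl nor 4-(trifluoromethyl)phenyl on this nitrogen is among the compounds shown.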